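Chain extension on the sulfur side of the shared core

The source may report more compounds than this note shows. Statements on the series, on what has been measured and on what is new or still open speak of the compounds shown alone.

Compounds measured so far:
compound 1 `CCCSC[C@H](NC(C)=O)C(=O)CCl` — 8000 nM
compound 2 `CCCCSC[C@H](NC(C)=O)C(=O)CCl` — 5600 nM
compound 3 `CCCCCCCCCSC[C@H](NC(C)=O)C(=O)CCl` — 6700 nM

In a functional assay on MOLT-3 cells (Homo sapiens) (a lower number here means a stronger inhibitor, a higher number a weaker inhibitor), the three values sit close together. Compound 3 holds the second highest number of the three; its nearest neighbour is compound 1 and its furthest is compound 2, and both gaps fall within the scatter.

The next compound is compound 4 `CCCCCCCCCCCCCSC[C@H](NC(C)=O)C(=O)CCl`. It differs from compound 3 by butyl in place of hydrogen on a saturated chain carbon, nine bonds along the chain from a sulfur.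

For the measured compounds named here, three measured steps bear on this change, all of them lengthenings of the same chain: a 1.4-fold lower number from compound 1 to compound 2 (0.15 log units; within the scatter), a 1.2-fold lower number from compound 1 to compound 3 (0.08 log units; within the scatter) and a 1.2-fold higher number from compound 2 to compound 3 (0.08 log units; within the scatter). None of them moved this assay beyond the scatter, and neither a short nor a long addition to the chain did so. On that basis no step beyond the scatter is expected from compound 3 to compound 4 in either direction, that is, an expected step of no change at the digits printed from compound 3 to compound 4 (within the scatter).

For compound 4 the estimated value in this assay is 6700 nM, with a range from 3000 nM to 15000 nM.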

Compound 4, half-maximal inhibitory concentration: > 100000 nM
Compound 4 gave a limit, no number; the forecaster's own chance of this, stated with the estimate: 5%; middle value at least 14-fold (1.17 log units) from the limit.
By their numbers in this assay, from the lowest: compounds 2, 3 and 1 (each within the scatter of the next). At a limit, above all of these: compound 4.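

Butyl in place of hydrogen on a saturated chain carbon, nine bonds along the chain from a sulfur, gives an at least 14-fold higher number from compound 3 to compound 4 (1.17 log units; beyond the scatter) in this assay, the only step in this chain series that lies beyond the scatter. The flat stretch seen across compounds 1, 2 and 3 therefore does not extend to compound 4, and chain length on the sulfur side of the shared core is not neutral without bound. The result for compound 4 is a limit and not a number: the limit of > 100000 nM in this assay, at which 1 of the 4 values shown sits.

The compounds shown do not fix where along the chain between compound 3 and compound 4 the loss sets in, nor do they give its cause. Also open, from the compounds shown here alone, is whether a long chain ending in a carboxylic acid or an amine would keep the level of compound 3.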